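Methyl for fluoro on the fused ring of an aldosterone synthase inhibitor

A few compounds are considered here, and "the series" means these few. Any claim that something is new, unique, unknown or untested is made for them only; others in the source may bear on it.

Of the compounds shown here, three sharing one core have been measured in an assay on cells for inhibition of cytochrome P450 11B2, mitochondrial (Homo sapiens), read by HTRF, with stated times of 1 h and 3 h; a higher number here means a weaker inhibitor, a lower number a stronger inhibitor. Compound 1 `CC(C)(O)c1cncc(-n2ncc3ccccc32)c1` gives 15 nM. Compound 2 `Cc1nn(-c2cncc(C(C)(C)O)c2)c2ccccc12` gives 33.5 nM, and compound 3 `CC(C)(O)c1cncc(-n2ncc3c(F)cccc32)c1` gives 7.58 nM. Compound 3 holds the lowest number of the three: compound 1 is nearest, and the gap a 2.0-fold lower number from compound 1 to compound 3 (0.30 log units; within the scatter) lies within the scatter, while compound 2 is furthest, its number higher beyond the scatter.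

Compound 4 `Cc1cccc2c1cnn2-c1cncc(C(C)(C)O)c1` is not yet measured. It differs from compound 3 by methyl in place of fluoro on an aromatic carbon. Going by the values given here, two measured steps bear on this. Placing fluoro at this carbon gave a 2.0-fold lower number from compound 1 to compound 3 (0.30 log units; within the scatter), within the scatter. Placing methyl on the core gave a 2.2-fold higher number from compound 1 to compound 2 (0.35 log units; beyond the scatter), a modest loss, though compound 2 carries its methyl on another aromatic carbon, so that step is only an indirect guide. Together they suggest that swapping fluoro for methyl at this carbon is expected to give a step of about a 1.8-fold higher number from compound 3 to compound 4 (0.27 log units; within the scatter) in this assay, not clearly beyond the scatter. Compound 4 is therefore estimated at 14 nM, within a range from 6 nM to 40 nM.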

Compound 4, half-maximal inhibitory concentration: 7.77 nM
For compound 4 the middle estimate is 1.8-fold (0.26 log units) above the measured one; the measured number falls inside the stated range.
By their numbers in this assay, from the lowest: compounds 3, 4 and 1 (each within the scatter of the next); then compound 2.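

In this assay, replacing fluoro with methyl at this aromatic carbon gives a 1.0-fold higher number from compound 3 to compound 4 (0.01 log units; within the scatter), so the two groups cannot be told apart here. Placing methyl at this carbon in place of hydrogen gives a 1.9-fold lower number from compound 1 to compound 4 (0.29 log units; within the scatter), whereas methyl on the other aromatic carbon gave a 2.2-fold higher number from compound 1 to compound 2 (0.35 log units; beyond the scatter), so among these compounds the result of adding methyl differs with the carbon that carries it. Neither fluoro nor methyl at this carbon moves the number beyond the scatter from that of compound 1.

No supporting data are available to explain why fluoro and methyl read alike at this carbon. The compounds shown leave open whether a methoxy group, a trifluoromethyl group or an amine at this carbon would also stay within the scatter of compound 1.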